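Compound 3: Expected to Stay at the Assay Limit

The source may hold more compounds than are shown below. What is called first, only, known or untested is meant among the compounds shown, and "the series" means these compounds.

Compound 1 `OC[C@H]1O[C@@H](n2cnc3c(NCc4ccccc4F)ncnc32)[C@H](O)[C@@H]1O`: in a functional assay on MCF cells (Homo sapiens) for antiproliferative activity, with a stated time of 72 h (on this read-out lower numbers stand for stronger inhibition and higher numbers for weaker inhibition), compound 1 gives > 166000 nM, which is a limit rather than a number.
Compound 2 `COc1ccccc1CNc1ncnc2c1ncn2[C@@H]1O[C@H](CO)[C@@H](O)[C@H]1O`: in this assay compound 2 gives > 166000 nM, again only a limit.

Compound 2 therefore stands only at a limit, as both measured values do (the limit of > 166000 nM in this assay, at which 2 of the 2 values shown sit). Going by the values given here, the single measured step, a step that the two limits leave unreadable from compound 1 to compound 2, stays unreadable. Compound 3 `OC[C@H]1O[C@@H](n2cnc3c(NCc4cccc(C(F)(F)F)c4)ncnc32)[C@H](O)[C@@H]1O` arises through (3-(trifluoromethyl)phenyl in place of 2-methoxyphenyl on a saturated chain carbon bound to a nitrogen on an aromatic ring). No readable step bears on this change, so no direction can be drawn from the data. Compound 3 is expected to give 166000 nM, within 50000 nM to 500000 nM, most likely again as a limit. The expected step is a number no higher from compound 2 to compound 3 (the limit leaves the size open).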

Compound 3, half-maximal inhibitory concentration: > 166000 nM
Compound 3: only a limit was reported; the forecaster's own chance of this, stated with the estimate: 75%; the middle value sits exactly at the limit.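

Compound 1, compound 2 and compound 3 all stop at the assay limit, so no step among them can be read: the limit of > 166000 nM in this assay, at which 3 of the 3 values shown sit.

What the compounds shown leave open is how strongly any of them inhibits, and whether changing the aromatic group alters that at all.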